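Trimming a methyl from the weakest of three indolinones

The source may report more compounds than this note shows. Statements on the series, on what has been measured and on what is new or still open speak of the compounds shown alone.

Of the compounds shown here, three built on a shared core have been measured in a functional assay on cells (Cancer cell lines, Homo sapiens) for cytotoxicity, with a stated time of 48 h; on this read-out lower numbers stand for stronger inhibition of growth and higher numbers for weaker inhibition of growth. For the measured compounds named here, compound 1 `COc1cc2c(/C=C3/C(=O)Nc4ccc(O)cc43)c(Cl)n(Cc3cc(OC)c(OC)c(OC)c3)c2cc1C` gives 1410 nM, and compound 2 `COc1cc2c(/C=C3/C(=O)Nc4ccc(Cl)cc43)c(Cl)n(Cc3cc(OC)c(OC)c(OC)c3)c2cc1C` gives 2090 nM; the only single change between measured compounds, a 1.5-fold higher number from compound 1 to compound 2 (0.17 log units; within the scatter), is therefore small. Compound 3 `COc1cc2c(cc1C)NC(=O)/C2=C/c1c(Cl)n(Cc2cc(OC)c(OC)c(OC)c2)c2cc(C)c(OC)cc12` gives 10000 nM, the highest of the three numbers, and so the weakest grower-inhibitor in the set: its gap to compound 2 and to compound 1 lies beyond the scatter.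

Compound 4 `COc1ccc2c(c1)/C(=C\c1c(Cl)n(Cc3cc(OC)c(OC)c(OC)c3)c3cc(C)c(OC)cc13)C(=O)N2` differs from compound 3 by one alteration: hydrogen in place of methyl on an aromatic carbon. The group is removed from the six-membered carbon-only ring of the fused two-ring system, ortho to a methoxy group, meta to a fused ring and para to a fused ring.

Going by the values given here, no measured step touches this position or this kind of change; the single step available, from compound 1 to compound 2, swaps one group for another at a different ring and stays within the scatter. With nothing in the data pointing to a large effect, the expectation is a step of a 1.7-fold lower number from compound 3 to compound 4 (0.22 log units; within the scatter), a modest change that may well stay within the scatter. Compound 4 is thus estimated at 6000 nM, with a range from 2500 nM to 15000 nM.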

Compound 4, concentration for 50% growth inhibition: 10200 nM
For compound 4 the middle estimate is 1.7-fold (0.23 log units) below the measured one, within the range that was stated.
By their numbers in this assay, from the lowest: compounds 1 and 2 (each within the scatter of the next); then compounds 3 and 4 (each within the scatter of the next).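

Removing the methyl from the aromatic carbon ortho to a methoxy group gives a 1.0-fold higher number from compound 3 to compound 4 (0.01 log units; within the scatter) in this assay, so for this pair the methyl can be replaced by hydrogen without a change this read-out can resolve. For the compounds shown here, compound 4 also links this pair to the earlier compounds through a second place, the one that carries hydroxy in compound 1 and chloro in compound 2. Exchanging chloro for methoxy there gives a 4.9-fold higher number from compound 2 to compound 4 (0.69 log units; beyond the scatter) and adding a methyl to the hydroxy oxygen gives a 7.2-fold higher number from compound 1 to compound 4 (0.86 log units; beyond the scatter), while the exchange of hydroxy for chloro stays small at a 1.5-fold higher number from compound 1 to compound 2 (0.17 log units; within the scatter), so among these compounds methoxy at that place stands apart from hydroxy and chloro, and the methyl removal does not alter the number. No measurement shown here accounts for these steps.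

The compounds shown do not tell whether an amine or a carboxylic acid on the aromatic carbon that lost the methyl would also leave the number unchanged. They also leave open whether removing that methyl would have so little effect with hydroxy or chloro in place of the methoxy at the second place.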